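Swapping the amide acyl group on a histamine H3 ligand

The source may hold more compounds than are shown below. What is called first, only, known or untested is meant among the compounds shown, and "the series" means these compounds.

Measured so far:
compound 1, `CC(=O)N1CCCC1C(=O)Nc1ccc(N2CCC(N3CCCC3C)C2)c(C)c1`, 44.9 nM
compound 2, `Cc1cc(N2CCC(N3CCCC3C)C2)ccc1NC(=O)C1CCOCC1`, 6.8 nM
compound 3, `CC1CCCN1C1CCN(c2ccc(NC(=O)C3CC3)cc2)C1`, 9.7 nM

Of the compounds shown here, three have been tested in an assay on CHO cells for displacement of a labelled ligand from histamine receptor H3 (Macaca mulatta); a lower number here means a stronger inhibitor, a higher number a weaker inhibitor. Compound 1 gives the highest number of the three, and its closest neighbour is compound 3 at 9.7 nM, while compound 2 at 6.8 nM lies furthest from it; both of these gaps lie beyond the scatter, so compound 1 is the weakest inhibitor of the set.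

Compound 4, `Cc1cc(NC(=O)C2CCOCC2)ccc1N1CCC(N2CCCC2C)C1`, has not yet been measured. It differs from compound 1 in one place: oxan-4-yl in place of 1-acetylpyrrolidin-2-yl on a carbonyl carbon. The rest of the molecule is kept as in compound 1. Within the data shown here, the same oxan-4-yl amide appears in compound 2, although compound 2 differs from compound 4 elsewhere in the core, so no direct step is available.

Since the two smaller acyl groups in compound 2 and compound 3 go with clearly lower numbers than compound 1, the step of a 4.5-fold lower number from compound 1 to compound 4 (0.65 log units; beyond the scatter) is expected to be a clear drop in this assay. Compound 4 is therefore estimated at 10 nM, with a range from 4 nM to 25 nM.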

Compound 4, inhibition constant: 17 nM
For compound 4 the middle estimate is 1.7-fold (0.23 log units) below the measured one, and the stated range covers the measured number.
By their numbers in this assay, from the lowest: compounds 2, 3 and 4 (each within the scatter of the next, the first and the last beyond it); then compound 1.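

In this assay, among these compounds, exchanging the 1-acetylpyrrolidin-2-yl group for an oxan-4-yl group gives a 2.6-fold lower number from compound 1 to compound 4 (0.42 log units; beyond the scatter) and is the first change in this set that can be read with the rest of the molecule held fixed. It shows that the group at this position alone moves the number beyond the scatter, although the step is modest, whereas compound 2 and compound 3 differ from compound 1 in more than one place and could not show this. The step replaces a five-membered non-aromatic ring of 8 heavy atoms with a six-membered non-aromatic ring of 6 heavy atoms and removes the double bond outside aromatic rings, while both groups count 0 hydrogen-bond donors and 1 hydrogen-bond acceptor, and no measurement shown explains why the number changes.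

The compounds shown leave open whether a 1-acetylpyrrolidin-2-yl group stripped of its acetyl, with a free ring amine, or an open alkyl chain on the same carbonyl carbon would lie nearer compound 1 or compound 4. They also leave open whether this exchange would give a step of similar size on the core of compound 2 or compound 3.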